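Moving the chlorine on the phenyl ring of compound 1

The source may hold more compounds than are shown below. What is called first, only, known or untested is meant among the compounds shown, and "the series" means these compounds.

Measured compounds:
- compound 1 `Cn1c(-c2cccc(Cl)c2)nc2c(NC3CCCC3)ncnc21`: 2530 nM
- compound 2 `CCCn1c(-c2ccccc2)nc2c(NC3CCOC3)ncnc21`: 9080 nM
- compound 3 `Cn1c(-c2ccccc2)nc2c(NC3CCOC3)ncnc21`: 13300 nM

In a functional assay on CHO cells for antagonist activity at adenosine receptor A2b (Homo sapiens), read by 33P incorporation, with a stated time of 20 min (on this read-out lower numbers stand for stronger inhibition and higher numbers for weaker inhibition), compound 1 gives 2530 nM, the lowest number of the three. Compound 2 gives 9080 nM and compound 3 gives 13300 nM; both gaps to compound 1 are beyond the scatter, so compound 1 inhibits more strongly than either.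

Compound 4 `Cn1c(-c2ccccc2Cl)nc2c(NC3CCCC3)ncnc21` differs from compound 1 in one place: 2-chlorophenyl in place of 3-chlorophenyl on an aromatic carbon. For the measured compounds named here, the only measured step, a 1.5-fold higher number from compound 2 to compound 3 (0.17 log units; within the scatter), concerns the chain on the ring nitrogen and not the phenyl ring, so no measured step bears on this change. The data give no guide to whether shifting the chlorine matters, so the expectation is no change beyond the scatter, with wide uncertainty.

Compound 4 is therefore estimated at 3000 nM, within 900 nM to 10000 nM, an expected step of a 1.2-fold higher number from compound 1 to compound 4 (0.07 log units; within the scatter).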

Compound 4, inhibition constant: > 30000 nM
Compound 4: no number, only a limit; the forecaster's own chance of this, stated with the estimate: 5%; middle value at least 10-fold (1.00 log units) away from the limit.
By their numbers in this assay, from the lowest: compound 1; then compounds 2 and 3 (each within the scatter of the next). At a limit, above all of these: compound 4.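

In this assay compound 4 gives > 30000 nM, which is a limit of the assay and not a number. Replacing 3-chlorophenyl with 2-chlorophenyl gives an at least 11-fold higher number from compound 1 to compound 4 (1.07 log units; beyond the scatter), a large loss of inhibition, even though the two compounds hold the same atoms, joined differently. The earlier compounds shown here tested only the chain on the ring nitrogen, whereas this pair shows that, on the aromatic carbon between two ring nitrogen atoms, the place of the chlorine on the phenyl ring alone can separate measurable inhibition from a limit.

The compounds shown do not explain why the chlorine's place matters so much. Also open, on these data alone, is whether fluorine or a methoxy group in place of the chlorine of 2-chlorophenyl would give the same result.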